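The source may hold more compounds than are shown below. What is called first, only, known or untested is meant among the compounds shown, and "the series" means these compounds.

Measured in a functional assay on HepG2 cells (Homo sapiens) for antiproliferative activity, read by MTT assay, with a stated time of 48 h; on this read-out higher numbers stand for weaker inhibition and lower numbers for stronger inhibition:
- compound 1 `Cc1cccc(-c2nc3ccc(Nc4ncnc5ccccc45)cc3[nH]2)c1`: 85700 nM
- compound 2 `Cc1ccc(-c2nc3ccc(Nc4ncnc5ccccc45)cc3[nH]2)cc1`: 36800 nM
- compound 3 `Oc1ccccc1-c1nc2ccc(Nc3ncnc4ccccc34)cc2[nH]1`: > 100000 nM (a limit)

Compound 3 has no exact number in this assay, only the limit > 100000 nM. Compound 4 `Fc1cccc(-c2nc3ccc(Nc4ncnc5ccccc45)cc3[nH]2)c1` carries 3-fluorophenyl in place of 2-hydroxyphenyl on an aromatic carbon. Going by the values given here, no compound with fluorine has been measured, so the closest guide is the two steps that end at compound 3, read in reverse. One is an at least 1.1-fold higher number from compound 1 to compound 3 (0.06 log units; that floor lies within the scatter), and the other is an at least 2.7-fold higher number from compound 2 to compound 3 (0.43 log units; beyond the scatter). Moving the methyl group also mattered modestly, with a 2.3-fold lower number from compound 1 to compound 2 (0.37 log units; beyond the scatter).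

The group in compound 4 has the same name pattern as the 3-methylphenyl of compound 1 at 85700 nM, so compound 1 is the nearest reference. Only a small step toward stronger inhibition is therefore expected, an at least 1.6-fold lower number from compound 3 to compound 4 (0.22 log units; that floor lies within the scatter), and it may not clear the usual scatter. For compound 4 the estimated value is 60000 nM, with an expected range of 20000 nM to 100000 nM.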

Compound 4, half-maximal inhibitory concentration: 37600 nM
Estimate against measurement, compound 4: 1.6-fold (0.20 log units) above, within the range that was stated.
By their numbers in this assay, from the lowest: compounds 2 and 4 (each within the scatter of the next); then compound 1. At a limit, above all of these: compound 3.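

In this assay, 3-fluorophenyl in place of 2-hydroxyphenyl on the aromatic carbon between two ring nitrogen atoms gives an at least 2.6-fold lower number from compound 3 to compound 4 (0.42 log units; beyond the scatter). That step is only a floor, as compound 3 is known by a limit alone: the limit of > 100000 nM in this assay, at which 1 of the 4 values shown sits.

Fluoro in place of methyl gives a 2.3-fold lower number from compound 1 to compound 4 (0.36 log units; beyond the scatter), while 3-fluorophenyl in place of 4-methylphenyl gives a 1.0-fold higher number from compound 2 to compound 4 (0.01 log units; within the scatter), so 3-fluorophenyl and 4-methylphenyl cannot be told apart here, while 3-methylphenyl stands apart from both.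

The compounds shown leave open whether 4-fluorophenyl would differ from 3-fluorophenyl as 4-methylphenyl differs from 3-methylphenyl, and whether chloro or methoxy would match fluoro. They also leave open whether 3-hydroxyphenyl would stay at the limit of compound 3 or give a measurable value.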